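Cytotoxicity notes on extending the chain from compound 2

A few compounds are considered here, and "the series" means these few. Any claim that something is new, unique, unknown or untested is made for them only; others in the source may bear on it.

Compound 1 `Cn1c(N)c(-c2nc3ccccc3[nH]2)c2nc(C#N)c(C#N)nc21` and compound 2 `CCn1c(N)c(-c2nc3ccccc3[nH]2)c2nc(C#N)c(C#N)nc21` share one core. In an ADME assay on HEK293 cells (Homo sapiens) for cytotoxicity, read by MTT assay, with a stated time of 48 h (on this read-out lower numbers stand for stronger inhibition and higher numbers for weaker inhibition), compound 1 gives > 50000 nM, which is a limit of the assay and not a number. In this assay compound 2 gives > 50000 nM, likewise a limit. For the measured compounds named here, the one measured step, a step that the two limits leave unreadable from compound 1 to compound 2, is therefore unreadable in size. Going by the values given here, compound 2 stands at the limit, and the only evidence on record is the limit of > 50000 nM in this assay, at which 2 of the 2 values shown sit.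

Compound 3 `CN1CCN(CCCn2c(N)c(-c3nc4ccccc4[nH]3)c3nc(C#N)c(C#N)nc32)CC1` is the next member to be measured. It differs from compound 2 by (4-methylpiperazin-1-yl)methyl in place of hydrogen on a saturated chain carbon, two bonds along the chain from an aromatic nitrogen. Among the compounds with values here, no measured step bears on this change in a readable way: a step that the two limits leave unreadable from compound 1 to compound 2 touches the same chain but its size is hidden by the two limits. With both shown values sitting at the limit, no direction can be drawn from the series, and the expected outcome for compound 3 in this assay is a further limit rather than a number. The estimate for compound 3 is 50000 nM, with a range from 15000 nM to 150000 nM. The step implied, a number no higher from compound 2 to compound 3 (the limit leaves the size open), is expected to be none beyond the scatter.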

Compound 3, half-maximal inhibitory concentration: 6260 nM
Beside the measured number, compound 3's estimate is 8.0-fold (0.90 log units) above it; measured number outside the range, below it.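

In this assay, (4-methylpiperazin-1-yl)methyl in place of hydrogen on a saturated chain carbon, two bonds along the chain from an aromatic nitrogen, gives an at least 7.9-fold lower number from compound 2 to compound 3 (0.90 log units; beyond the scatter), so a change at this position can bring the read-out off the limit to a readable number. Measured from the shorter member, the same ring-bearing chain gives an at least 7.9-fold lower number from compound 1 to compound 3 (0.90 log units; beyond the scatter), and both steps are minimum sizes, as each starts from a limit of the assay and not a number. The step from compound 1 to compound 2 still cannot be read, and compound 3 is the only member with a number, so the limit remains the common ground of the two shorter members: the limit of > 50000 nM in this assay, at which 2 of the 3 values shown sit.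

On these data alone, it stays open whether the lower number goes with the 4-methylpiperazin-1-yl ring or with the longer chain alone, a question on which a plain propyl chain or a 3-(morpholin-4-yl)propyl group in the same place would bear. Also open, as far as these compounds go, is how the number moves when the same ring sits on a butyl chain.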